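Trimming the Amide Chain from Propyl to Ethyl

The source may report more compounds than this note shows. Statements on the series, on what has been measured and on what is new or still open speak of the compounds shown alone.

Of the compounds shown here, three sharing one core have been tested in a functional assay on HeLa cells (Homo sapiens) for antiproliferative activity, read by CCK-8 assay, with a stated time of 72 h; on this read-out lower numbers stand for stronger inhibition of growth and higher numbers for weaker inhibition of growth. Compound 1 `CCCCNC(=O)c1ccc2c(ccn2-c2ncc3c(n2)N(c2ccn(C)n2)C(CC)C(=O)N3C)c1` gives 4260 nM, compound 2 `CCC1C(=O)N(C)c2cnc(-n3ccc4cc(C(=O)NC5CCCC5)ccc43)nc2N1c1ccn(C)n1` gives 27400 nM, and compound 3 `CCCNC(=O)c1ccc2c(ccn2-c2ncc3c(n2)N(c2ccn(C)n2)C(CC)C(=O)N3C)c1` gives 6160 nM. Compound 3 thus sits second highest of the three numbers, close to compound 1 and well apart from compound 2: the step of a 1.4-fold higher number from compound 1 to compound 3 (0.16 log units; within the scatter) stays within the scatter, whereas a 4.4-fold lower number from compound 2 to compound 3 (0.65 log units; beyond the scatter) and a 6.4-fold higher number from compound 1 to compound 2 (0.81 log units; beyond the scatter) lie beyond it.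

Compound 4 `CCNC(=O)c1ccc2c(ccn2-c2ncc3c(n2)N(c2ccn(C)n2)C(CC)C(=O)N3C)c1` carries the same core and differs from compound 3 only at the amide chain: hydrogen in place of methyl on a saturated chain carbon, two bonds along the chain from an amide-type nitrogen. Going by the values given here, the change most like it is the one from compound 1 to compound 3, which also shortened this chain by one carbon and produced only a 1.4-fold higher number from compound 1 to compound 3 (0.16 log units; within the scatter). The two steps involving compound 2 exchange a chain for a ring, so they speak less directly to a further shortening. On that basis the step to compound 4 is expected to be small, and if anything toward a slightly higher number in this assay, most likely within the scatter. Compound 4 is therefore estimated at 8000 nM, with a range from 3500 nM to 18000 nM, which corresponds to an expected step of a 1.3-fold higher number from compound 3 to compound 4 (0.11 log units; within the scatter).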

Compound 4, concentration for 50% growth inhibition: 11100 nM
The estimate for compound 4 lay 1.4-fold (0.14 log units) below the measured number; low and high end bracket the measured number.
By their numbers in this assay, from the lowest: compounds 1, 3 and 4 (each within the scatter of the next, the first and the last beyond it); then compound 2.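

In this assay, the step from propyl to ethyl (a 1.8-fold higher number from compound 3 to compound 4 (0.26 log units; within the scatter)) stays within the scatter, as the step from butyl to propyl did, yet the two ends of this short series can be told apart (a 2.6-fold higher number from compound 1 to compound 4 (0.42 log units; beyond the scatter)), so the chain length at this position shows an effect on growth inhibition that neither single step could show alone. The ethyl amide also remains clearly separate from the cyclopentyl amide (a 2.5-fold lower number from compound 2 to compound 4 (0.39 log units; beyond the scatter)), which leaves compound 2 beyond the scatter from each of the three straight-chain compounds, including the one closest to it in number. No measured evidence is available to explain these differences.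

The compounds shown leave open whether the trend continues to a methyl group on the amide nitrogen or to the amide with only hydrogen there, and whether a longer chain such as pentyl would give a lower number than butyl. They also leave open how a chain ending in an amine or a carboxylic acid would behave at this position.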